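The compounds below may be only part of what the source reports. "The series", "measured", "known", "first", "only" and "open" are said of these compounds alone.

Measured in an ADME assay on BJ cells (Homo sapiens) for cytotoxicity, with a stated time of 72 h; on this read-out lower numbers stand for an effect already at smaller amounts and higher numbers for an effect only at larger amounts of compound:
- Compound 1 `C=C[C@@](C)(/C=C/c1ccc(O)c(/C=C/c2ccc(Cl)cc2)c1)CCC=C(C)C`: > 36600 nM
- Compound 2 `CCOc1ccc(/C=C/[C@@](C)(/C=C/c2ccc(O)cc2)CCC=C(C)C)cc1`: > 36600 nM

Neither entry is a number. In this assay compound 1 gives > 36600 nM, which is a limit of the assay. Compound 2 gives > 36600 nM, which is likewise a limit and not a number. Compound 2 therefore has no exact position, and the record so far is the limit of > 36600 nM in this assay, at which 2 of the 2 values shown sit.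

Compound 3 `CC(C)=CCC[C@](C)(/C=C/c1ccc(O)cc1)/C=C/c1ccc(C#N)cc1` is still to be measured. It differs from compound 2 at one place, para to a large group, so that 4-ethoxyphenyl becomes 4-cyanophenyl: cyano in place of ethoxy on an aromatic carbon. Within the data shown here, no measured pair in this set shows what such a change does in this assay.

The expectation rests on compound 2, whose limit is > 36600 nM. No step beyond the usual scatter is expected, and a reading at the same limit is the likeliest outcome. The expected step of an at least 1.0-fold lower number from compound 2 to compound 3 (0.00 log units; that floor lies within the scatter) is accordingly small and has no firm direction. For compound 3 the estimated value is 36000 nM, with an expected range from 15000 nM to 50000 nM.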

Compound 3, half-maximal effective concentration: > 36600 nM
Compound 3: a limit, no number (the forecaster's own chance of this, stated with the estimate: 70%); middle value at least 1.0-fold (0.00 log units) away from the limit.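

In this assay compound 3 gives > 36600 nM, which is a limit of the assay and not a number. Compound 2 also stands at a limit, so no step can be read between compound 2 and compound 3. The compounds shown leave open what cyano in place of ethoxy does to the read-out, and where any of them would fall as a number: the limit of > 36600 nM in this assay, at which 3 of the 3 values shown sit.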